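The compounds below may be only part of what the source reports. "The series", "measured", "known", "first", "only" and "open" are said of these compounds alone.

Working notes on the sulfonylurea series.

The read-out is a functional assay on the whole organism (6C3HED cells, Mus musculus) for inhibition, at a dose of 150 mg/kg by the oral route; on this read-out higher numbers stand for more inhibition at the one dose given (going by the name of the read-out) and lower numbers for less inhibition. Compound 1, `CCc1ccc(S(=O)(=O)NC(=O)Nc2ccc(Cl)cc2)o1`, gives 57%. Compound 2, `Cc1ccsc1S(=O)(=O)NC(=O)Nc1ccc(Cl)cc1`, gives 17%. For the measured compounds named here, the single step between measured compounds, a number 40 percentage points lower from compound 1 to compound 2 (beyond the scatter), pairs a change of the ring on the sulfonyl sulfur with a change of the chain on that ring, so the two cannot be separated on these numbers. On the numbers shown compound 2 stands lowest of the two, with compound 1 as its only neighbour and well beyond the scatter above it.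

The unmeasured compound 3 is `CCc1ccsc1S(=O)(=O)NC(=O)Nc1ccc(Cl)cc1`. Relative to compound 2 the change is methyl in place of hydrogen on a saturated chain carbon bound to an aromatic carbon. Going by the values given here, no measured step isolates this change; the step from compound 1 to compound 2 is the only one that touches the chain on the sulfonyl-bearing ring, and it does so together with a ring change, so it bears on the present step only indirectly. Given that compound 1, the ethyl-bearing compound, gives 57%, a rise for compound 3 is plausible but not secured. The expected step is a number 13 percentage points higher from compound 2 to compound 3 (beyond the scatter), of a size that may or may not pass beyond the scatter. Compound 3 is estimated at 30%, with a range from 10% to 55%.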

Compound 3, a percentage reported as inhibition, in the whole organism at one dose (the size of the read-out at that dose, not a potency): 21%
Beside the measured number, compound 3's estimate is 9 percentage points above it, within the range that was stated.
By their numbers in this assay, from the lowest: compounds 2 and 3 (each within the scatter of the next); then compound 1.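

In this assay, lengthening the chain on the sulfonyl-bearing ring from 3-methylthiophen-2-yl to 3-ethylthiophen-2-yl gives a number 4 percentage points higher from compound 2 to compound 3 (within the scatter) and so has no effect that can be told from the usual scatter, which means that ethyl as such does not restore the level of compound 1. With an ethyl group present in both compounds, the gap remains as a number 36 percentage points lower from compound 1 to compound 3 (beyond the scatter) for 3-ethylthiophen-2-yl in place of 5-ethylfuran-2-yl, placing the large difference with the ring and the place of the ethyl rather than with the presence of the ethyl. No measurement bears on the reason for either step.

That second step still joins the identity of the ring to the place of the chain, so the two remain unseparated; 5-ethylthiophen-2-yl or 3-ethylfuran-2-yl would bear directly on that question. From the compounds shown here alone, whether the flat response at this chain carbon holds for a longer chain such as propyl, or for a hydroxymethyl or carboxylic acid group, remains open.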